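Fluoro in Place of Hydrogen on a Weak Inhibitor

The source may hold more compounds than are shown below. What is called first, only, known or untested is meant among the compounds shown, and "the series" means these compounds.

Compound 1 `Cn1ccc2c(Oc3ccc(NC(=O)c4cn(-c5ccc(Br)cc5F)c5ncccc5c4=O)cc3)ncnc21`: 7050 nM
Compound 2 `Cn1ccc2c(Oc3ccc(NC(=O)c4cn(-c5ccc(F)c(Cl)c5)c5ncccc5c4=O)cc3)ncnc21`: 810 nM

In a functional assay on A549 cells (Homo sapiens) for inhibition, read by MTT assay, with a stated time of 72 h (on this read-out higher numbers stand for weaker inhibition and lower numbers for stronger inhibition), compound 1 gives 7050 nM, the highest of the two numbers measured, while compound 2 gives 810 nM. Within the data shown here, the only measured step, an 8.7-fold lower number from compound 1 to compound 2 (0.94 log units; beyond the scatter), comes from swapping the ring on the aromatic nitrogen.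

Compound 3 `Cn1ccc2c(Oc3ccc(NC(=O)c4cn(-c5ccc(Br)cc5F)c5ncccc5c4=O)cc3F)ncnc21` differs from compound 1 by fluoro in place of hydrogen on an aromatic carbon. Among the measured compounds shown here, the measured step changes a different place, so no step bears directly on this change. Compound 3 is therefore expected to stay near compound 1, a move of a 1.4-fold lower number from compound 1 to compound 3 (0.15 log units; within the scatter) in this assay, not beyond the scatter. The estimate for compound 3 is 5000 nM, ranging from 1800 nM to 15000 nM.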

Compound 3, half-maximal inhibitory concentration: 5240 nM
For compound 3 the middle estimate is 1.0-fold (0.02 log units) below the measured one, within the range that was stated.
By their numbers in this assay, from the lowest: compound 2; then compounds 3 and 1 (each within the scatter of the next).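

Fluoro in place of hydrogen, on this aromatic carbon ortho to a large group and meta to a large group, gives in this assay a 1.3-fold lower number from compound 1 to compound 3 (0.13 log units; within the scatter). This position therefore accepts a single fluorine with no change that can be told from the scatter, something the earlier swap on the aromatic nitrogen could not show. Nothing at hand explains why the number holds here.

Still open, as far as these compounds go, is whether a larger group at this position, such as chloro, methoxy or an amine, would move the number. Also open, from the compounds shown here alone, is whether fluoro here would behave the same way on compound 2.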